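Changing the aryl group on a sulfonamide nitrogen

This account rests on a few compounds, and the source may have more. Where it says the series, first, only, none or still open, it means among the compounds named here.

In a functional assay on CHO-TAX 5-6 cells (Cricetulus griseus) for antiproliferative activity, read by sulforhodamine B assay, with a stated time of 48 h (a lower number here means a stronger inhibitor, a higher number a weaker inhibitor), compound 2 `O=C1NCCN1c1ccc(S(=O)(=O)Nc2cccc(Br)c2)cc1` gives 76 nM. Among the measured compounds shown here, its only measured neighbour, compound 1 `CCc1cccc(NS(=O)(=O)c2ccc(N3CCNC3=O)cc2)c1`, gives 140 nM, and these two values lie within the scatter of each other, so they cannot be ranked. For the measured compounds named here, the one measured step, bromo in place of ethyl on an aromatic carbon, is a 1.8-fold lower number from compound 1 to compound 2 (0.27 log units; within the scatter).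

The next structure is compound 3 `Cc1cc(C)cc(NS(=O)(=O)c2ccc(N3CCNC3=O)cc2)c1`. Its difference is 3,5-dimethylphenyl in place of 3-bromophenyl on a sulfonamide nitrogen. Going by the values given here, no measured compound carries 3,5-dimethylphenyl, so the data offer no direct test of this group, and a single step is thin evidence. That step does at least concern a similar swap on the same aromatic ring. A shift beyond the scatter in this assay is therefore not expected in either direction, since the change from compound 1 to compound 2 stayed within it at a 1.8-fold lower number from compound 1 to compound 2 (0.27 log units; within the scatter).

The expected size of the change is a 1.3-fold higher number from compound 2 to compound 3 (0.12 log units; within the scatter), which would be too small to read as a real difference. For compound 3 the estimated value is 100 nM, with an expected range from 35 nM to 280 nM.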

Compound 3, half-maximal inhibitory concentration: 120 nM
Compound 3: middle estimate off by 1.2-fold (0.08 log units), on the low side; low and high end bracket the measured number.
By their numbers in this assay, from the lowest: compounds 2, 3 and 1 (each within the scatter of the next).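

The step from the 3-bromophenyl group to the 3,5-dimethylphenyl group on the sulfonamide nitrogen is a 1.6-fold higher number from compound 2 to compound 3 (0.20 log units; within the scatter) in this assay and the step from the 3-ethylphenyl group to the same group is a 1.2-fold lower number from compound 1 to compound 3 (0.07 log units; within the scatter) and so neither step counts as a real difference. Compound 3 therefore adds a third aryl group to the comparison, and it shows that a ring with two methyl groups, rather than one group as in compound 1 and compound 2, gives a value that cannot be told apart from either neighbour, so compound 1, compound 2 and compound 3 cannot be ranked against one another. No independent measurement is available to account for this result.

From the compounds shown here alone, the aryl groups in compound 2 and compound 3 each count no hydrogen-bond donors or acceptors, so the effect of placing an amine or a carboxylic acid on this ring remains open. Going by these compounds, it is also open whether a longer chain, such as hexyl, in place of the ethyl of compound 1 would move the number beyond the scatter.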